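Swapping a Methylphenyl for Furanyl on an Oxadiazole Core

A few compounds are considered here, and "the series" means these few. Any claim that something is new, unique, unknown or untested is made for them only; others in the source may bear on it.

Compound 1, `COc1nc2ccccc2cc1/C=C/c1noc(-c2ccc(C)cc2)n1`, in an ADME assay on HepG2 cells (Homo sapiens) for cytotoxicity, read by sulforhodamine B assay, with a stated time of 48 h (a higher number here means that more compound is tolerated, a lower number that less compound is tolerated), gives > 230000 nM, which is a limit of the assay and not a number.
Compound 2, `COc1nc2ccccc2cc1/C=C/c1noc(-c2ccc(Br)cc2)n1`, in this assay gives > 195000 nM, again a limit.
Compound 3, `COc1nc2ccccc2cc1/C=C/c1noc(COc2ccccc2)n1`, in this assay gives > 220000 nM, also a limit.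

Compound 1 therefore stands nowhere exact on the scale: the three values shown are each a limit, at the limit of > 230000 nM in this assay, at which 1 of the 3 values shown sits, the limit of > 195000 nM in this assay, at which 1 of the 3 values shown sits, and (the limit of > 220000 nM in this assay, at which 1 of the 3 values shown sits), so none of them can be ranked against another. The steps measured so far, a step that the two limits leave unreadable from compound 1 to compound 2 and a step that the two limits leave unreadable from compound 1 to compound 3, bear on the change considered here in that each replaces or alters the group on the same aromatic carbon, but their sizes cannot be read because both ends are limits.

Compound 4, `COc1nc2ccccc2cc1/C=C/c1noc(-c2ccco2)n1`, differs from compound 1 by furan-2-yl in place of 4-methylphenyl on an aromatic carbon. With every measured value a limit and no readable step, no direction of change can be expected beyond the scatter, and the most likely outcome is that compound 4 also reaches the limit. Compound 4 is therefore expected to give about 230000 nM, within 90000 nM to 500000 nM, which is an estimated step of a number no higher from compound 1 to compound 4 (the limit leaves the size open).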

Compound 4, half-maximal cytotoxic concentration: > 250000 nM
Compound 4: no number, only a limit; the forecaster's own chance of this, stated with the estimate: 85%; middle value at least 1.0-fold (0.03 log units) from the limit.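

In this assay compound 4 gives > 250000 nM, which is a limit of the assay and not a number. Compound 1, compound 2 and compound 3 also give only limits, so none of the steps to compound 4 can be read. The compounds shown leave open whether exchanging 4-methylphenyl, 4-bromophenyl, phenoxymethyl and furan-2-yl changes the tolerated concentration at all.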